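The source may hold more compounds than are shown below. What is called first, only, known or untested is meant among the compounds shown, and "the series" means these compounds.

Of the compounds shown here, three built on a shared core have been measured in a physicochemical assay for solubility, read by turbidimetry, measured as kinetic solubility, at pH 6.8; on this read-out lower numbers stand for lower solubility and higher numbers for higher solubility. Compound 1 `COc1ccc(F)cc1N1C(=O)CSC1c1cccc(C(=O)NCCCCn2cccn2)c1` gives 50000 nM in this assay, and compound 3 `O=C(NCCCCn1cccn1)c1cccc(C2SCC(=O)N2c2cc(F)ccn2)c1` gives 50000 nM. For the measured compounds named here, the one single-point step among them, no change at the digits printed from compound 1 to compound 3 (within the scatter), exchanges the group on the amide-type nitrogen in the ring and leaves the read-out where it was. Compound 2 `O=C(NCCCCc1ccccc1)c1cccc(C2SCC(=O)N2c2cccc(F)c2)c1` gives 10000 nM in this assay, the lowest of the three numbers, with compound 1 and compound 3 both standing higher by margins beyond the scatter.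

Compound 4 `O=C(NCCCCc1ccccc1)c1cccc(C2SCC(=O)N2c2ccccc2F)c1` differs from compound 2 at that same nitrogen: 2-fluorophenyl in place of 3-fluorophenyl on an amide-type nitrogen in a ring. Going by the values given here, the only measured step that bears on this position is no change at the digits printed from compound 1 to compound 3 (within the scatter), which changed the whole group and still stayed within the scatter; here the same atoms are merely joined differently. The step from compound 2 to compound 4 is therefore expected to be small, no change at the digits printed from compound 2 to compound 4 (within the scatter), with no firm direction. Compound 4 is estimated at 10000 nM, within a range from 4000 nM to 25000 nM.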

Compound 4, solubility: 20000 nM
Beside the measured number, compound 4's estimate is 2.0-fold (0.30 log units) below it; the measured number falls inside the stated range.
By their numbers in this assay, from the lowest: compounds 2 and 4 (each within the scatter of the next); then compounds 1 and 3 (each within the scatter of the next).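

In this assay, the step of a 2.0-fold higher number from compound 2 to compound 4 (0.30 log units; within the scatter) stays within the scatter, so exchanging 3-fluorophenyl for 2-fluorophenyl on the amide-type nitrogen in the ring gives no readable shift. The earlier step at this nitrogen, no change at the digits printed from compound 1 to compound 3 (within the scatter), was also within the scatter, but it belonged to compounds carrying the pyrazole-ended chain, whereas this one holds among compounds carrying the phenyl-ended chain, so the read-out has now stayed within the scatter at this nitrogen with either chain end. No measured evidence is available to explain this result.

What the compounds shown leave open is whether a group of another kind on this nitrogen, such as a phenyl ring bearing an amine or a carboxylic acid, would move the read-out beyond the scatter. They also leave open how 4-fluorophenyl or unsubstituted phenyl would read at this position.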